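Trifluoromethoxy to ethoxy on the acid series

The compounds below may be only part of what the source reports. "The series", "measured", "known", "first", "only" and "open" are said of these compounds alone.

Measured in a physicochemical assay for lipophilicity, at pH 7.4; on this read-out lower numbers stand for lower lipophilicity and higher numbers for higher lipophilicity:
Compound 1 `CCOc1cc2[nH]c(Cc3nn(CC(=O)N4CCOCC4)c(=O)c4ccccc34)nc2cc1Cl`: 3.32
Compound 2 `O=C(O)Cn1nc(Cc2nc3cc(Cl)c(OC(F)(F)F)cc3[nH]2)c2ccccc2c1=O`: 2.54

Of these two numbers, compound 2 holds the lower, and the gap to compound 1 lies beyond the usual scatter. Compound 3 `CCOc1cc2[nH]c(Cc3nn(CC(=O)O)c(=O)c4ccccc34)nc2cc1Cl` differs from compound 2 by ethyl in place of trifluoromethyl on an oxygen on an aromatic ring in the same molecule. For the measured compounds named here, no measured pair shows this change alone, so the expectation rests on the structural change itself. In this assay a moderate downward step is expected, an estimated a number 0.44 log units lower from compound 2 to compound 3 (beyond the scatter) in all. For compound 3 the estimated value is 2.1 with an expected range from 1.7 to 2.5 in this read-out.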

Compound 3, distribution coefficient: 1.8
Compound 3: middle estimate off by 0.30 log units, on the high side; measured number inside the range.
By their numbers in this assay, from the lowest: compound 3; then compound 2; then compound 1.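

For the compounds shown here, with compound 3 in hand, the change from trifluoromethoxy to ethoxy on the acid series can be read alone for the first time: in this assay it gives a number 0.74 log units lower from compound 2 to compound 3 (beyond the scatter) with nothing else altered. Compound 3 also links the acid to the morpholine amide, as hydroxy in place of morpholin-4-yl on a carbonyl carbon gives a number 1.52 log units lower from compound 1 to compound 3 (beyond the scatter) on the ethoxy side. Nothing available explains either step. Still open, as far as these compounds go, is how a longer chain on the same oxygen would read, and how an amine other than morpholine would read on the carbonyl carbon.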